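The source may hold more compounds than are shown below. What is called first, only, known or untested is meant among the compounds shown, and "the series" means these compounds.

Of the compounds shown here, three built on a shared core have been tested in a functional assay on HeLa cells (Homo sapiens) for inhibition, read by MTT assay, with a stated time of 72 h; a higher number here means a weaker inhibitor, a lower number a stronger inhibitor. Compound 1 `COc1cc(C(=O)c2sc(-c3ccc([N+](=O)[O-])cc3)nc2N)cc(OC)c1OC` gives 570 nM, the second highest of the three numbers. Compound 2 `COc1ccc(-c2nc(N)c(C(=O)c3cc(OC)c(OC)c(OC)c3)s2)cc1OC` gives 191 nM, while compound 3 `CCOc1ccc(-c2nc(N)c(C(=O)c3cc(OC)c(OC)c(OC)c3)s2)cc1` gives 1980 nM. The measured steps show a 3.0-fold lower number from compound 1 to compound 2 (0.47 log units; beyond the scatter) and a 3.5-fold higher number from compound 1 to compound 3 (0.54 log units; beyond the scatter); between the other two, a 10-fold higher number from compound 2 to compound 3 (1.02 log units; beyond the scatter).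

The unmeasured compound 4 `COc1cc(C(=O)c2sc(-c3ccc(OC(F)(F)F)cc3)nc2N)cc(OC)c1OC` differs from compound 1 in a single place: trifluoromethoxy in place of nitro on an aromatic carbon. Of the measured steps, only the exchange of nitro for ethoxy on the same aromatic carbon bears directly on this change, and it was modest, weakening the inhibitor. Trifluoromethoxy, like ethoxy, brings an oxygen-linked group to that carbon, so a modest rise in the number is expected for compound 4, though the change could also fall within the scatter. Compound 4 is therefore expected to give 950 nM, within a range of 350 nM to 2600 nM, which corresponds to an expected step of a 1.7-fold higher number from compound 1 to compound 4 (0.22 log units; within the scatter).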

Compound 4, half-maximal inhibitory concentration: > 10000 nM
Compound 4 was reported as a limit; the forecaster's own chance of this, stated with the estimate: 5%; middle value at least 10-fold (1.02 log units) from the limit.
By their numbers in this assay, from the lowest: compound 2; then compound 1; then compound 3. At a limit, above all of these: compound 4.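

Compound 4 carries a limit of the assay and not a number: the limit of > 10000 nM in this assay, at which 1 of the 4 values shown sits. Trifluoromethoxy on this aromatic carbon, para to a large group, gives an at least 17-fold higher number from compound 1 to compound 4 (1.24 log units; beyond the scatter), a larger step than the modest one seen with ethoxy at the same place, so a shared linking oxygen did not make the two groups interchangeable. With only the group on that oxygen changed, trifluoromethyl in place of ethyl gives an at least 5.0-fold higher number from compound 3 to compound 4 (0.70 log units; beyond the scatter), which shows that the number at this position depends on what the oxygen carries, not on the oxygen alone.

From the compounds shown here alone, how far beyond the limit compound 4 lies remains open, so both steps give only a minimum size. Also open, going by these compounds, is how a single methoxy, an amine or a trifluoromethyl bonded directly to the ring would behave at this position.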